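This account rests on a few compounds, and the source may have more. Where it says the series, first, only, none or still open, it means among the compounds named here.

Compound 1, with the structure `Nc1nc(-c2ccccc2)c(C(=O)c2cnc3ccccn23)s1`, is the starting point of this set. In a functional assay on the whole organism (strain Sprague-Dawley) for inhibition, with Rattus norvegicus as the target, read by paw edema, with stated times of 1 h and 3 h, at a dose of 50 mg/kg by the oral route (on this read-out higher numbers stand for more inhibition at the one dose given (going by the name of the read-out) and lower numbers for less inhibition), compound 1 gives 40%. Compound 2, with the structure `Cc1ccn2c(C(=O)c3sc(N)nc3-c3ccccc3)cnc2c1`, carries one change relative to compound 1, namely (methyl in place of hydrogen on an aromatic carbon). In this assay compound 2 gives 26%, a step of a number 14 percentage points lower from compound 1 to compound 2 (beyond the scatter). Compound 3, with the structure `Nc1ncc(C(=O)c2cnc3ccccn23)s1`, differs from compound 1 in a single place as well, namely (hydrogen in place of phenyl on an aromatic carbon), and this is also how the cores of compound 3 and compound 4 differ from the core of compound 1 and compound 2. In this assay compound 3 gives 33%, a step of a number 7 percentage points lower from compound 1 to compound 3 (within the scatter).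

Compound 4, with the structure `Cc1ccc2ncc(C(=O)c3cnc(N)s3)n2c1`, has not yet been measured. It differs from compound 3 by methyl in place of hydrogen on an aromatic carbon. Among the compounds with values here, this is the same kind of change as the one from compound 1 to compound 2, but not the same: in that pair the methyl sits opposite the ring nitrogen, whereas in compound 4 it sits two atoms from the ring nitrogen. Because the earlier step of a number 14 percentage points lower from compound 1 to compound 2 (beyond the scatter) was a modest lowering, a lowering is expected here too, though a smaller one is taken as likely given the changed place on the ring, with an estimated step of a number 8 percentage points lower from compound 3 to compound 4 (within the scatter). Compound 4 is therefore expected to give 25% in this assay, with an estimated range from 12% to 38%.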

Compound 4, a percentage reported as inhibition, in the whole organism at one dose (the size of the read-out at that dose, not a potency): 53%
For compound 4 the middle estimate is 28 percentage points below the measured one, outside the stated range (above it).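

Methyl in place of hydrogen on an aromatic carbon can go with more inhibition in this series: this assay shows a number 20 percentage points higher from compound 3 to compound 4 (beyond the scatter). Set beside the earlier step, the same change does not keep its direction from one core to the other, so the effect seen on one of these cores cannot simply be carried over to the other: the same change on two cores in this assay, a number 14 percentage points lower (beyond the scatter) from compound 1 to compound 2 and a number 20 percentage points higher (beyond the scatter) from compound 3 to compound 4, 34 percentage points apart, beyond the scatter of two such steps What this does not show is why the two steps part, since the two pairs differ in more than the core: the methyl also sits at a different place on the ring, and with only these two pairs the contribution of the phenyl on the core of compound 1 cannot be separated from that of the methyl's place.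

The compounds shown leave open what the methyl would do at the same place on both cores, which is the comparison that would tell these two explanations apart. They also leave open whether a longer chain such as ethyl, a methoxy group or an amine on the same carbon as the methyl of compound 4 would go with a higher or a lower number in this assay.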